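The source may hold more compounds than are shown below. What is called first, only, known or untested is meant among the compounds shown, and "the series" means these compounds.

Compound 1, `CCCCOc1ccc(CN(Cc2ccc(C(C)(C)C)cc2)Cc2cc3cc(C)ccc3[nH]c2=O)cc1`: in a toxicity assay on MDCK cells (Canis lupus familiaris) for cytotoxicity, read by crystal violet staining, with a stated time of 48 h (on this read-out higher numbers stand for lower toxicity in this test and lower numbers for higher toxicity in this test), compound 1 gives > 5000 nM, a limit of the assay and not a number.
Compound 2, `Cc1ccc2[nH]c(=O)c(CN(Cc3ccc(C(C)(C)C)cc3)C(C)c3ccc(F)cc3)cc2c1`: in this assay compound 2 gives > 33000 nM, again a limit and not a number.

Compound 2 thus stands at the limit of > 33000 nM in this assay, at which 1 of the 2 values shown sits, while the other value shown sits at the limit of > 5000 nM in this assay, at which 1 of the 2 values shown sits. Among the compounds with values here, the only measured step, a step that the two limits leave unreadable from compound 1 to compound 2, has no readable size because both ends are limits. Compound 3, `Cc1ccc2[nH]c(=O)c(CN(Cc3ccc(C(C)(C)C)cc3)C(C)c3ccc(N(C)C)c(Cl)c3)cc2c1`, is not yet measured in this assay; it differs from compound 2 by 3-chloro-4-(dimethylamino)phenyl in place of 4-fluorophenyl on a saturated chain carbon bound to an amine nitrogen and a saturated chain carbon. Within the data shown here, no measured step with a readable size bears on this change, so there is no ground to expect a move beyond the usual scatter; the step from compound 2 to compound 3 is expected to be about an at least 1.1-fold lower number from compound 2 to compound 3 (0.04 log units; that floor lies within the scatter). Compound 3 is therefore estimated at 30000 nM, with a range from 8000 nM to 100000 nM, and quite possibly only a limit will be reported.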

Compound 3, half-maximal cytotoxic concentration: 9800 nM
Compound 3: middle estimate off by 3.1-fold (0.49 log units), on the high side; the range from low to high includes it.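

In this assay, within the data shown here, the saturated chain carbon bound to an amine nitrogen and a saturated chain carbon now gives the only readable change: 3-chloro-4-(dimethylamino)phenyl in place of 4-fluorophenyl brings an at least 3.3-fold lower number from compound 2 to compound 3 (0.52 log units; beyond the scatter). This swap of one aromatic group for another therefore moves the result towards higher toxicity in this test, and compound 3 is the only compound shown with an actual number. The size of this step is only a minimum because compound 2 has a limit and not a number: the limit of > 33000 nM in this assay, at which 1 of the 3 values shown sits.

The steps from compound 1 cannot be read. Going by these compounds, the chlorine and the dimethylamino group enter together, so it remains open whether 4-chlorophenyl or 4-(dimethylamino)phenyl alone at this place would give a similar change.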